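Benzyl changes on the shared core, growth inhibition notes

The compounds below may be only part of what the source reports. "The series", "measured", "known", "first", "only" and "open" are said of these compounds alone.

Values in a functional assay on HL-60 cells (Homo sapiens) for inhibition, read by CCK-8 assay, with a stated time of 48 h, tested at 20 uM (a lower number here means less inhibition of growth, a higher number more inhibition of growth at the concentration tested), so far
- compound 1 `COc1ccc(Cc2nnc(NC(=O)/C(C#N)=C/c3ccccc3OS(=O)(=O)c3ccc(C)cc3)s2)cc1` (25%)
- compound 2 `Cc1ccc(S(=O)(=O)Oc2ccccc2/C=C(\C#N)C(=O)Nc2nnc(Cc3cccc4ccccc34)s2)cc1` (19%)
- compound 3 `Cc1ccc(S(=O)(=O)Oc2ccccc2/C=C(\C#N)C(=O)Nc2nnc(Cc3cccc(F)c3)s2)cc1` (11%)
- compound 4 `Cc1ccc(S(=O)(=O)Oc2ccccc2/C=C(\C#N)C(=O)Nc2nnc(Cc3ccc(Cl)cc3)s2)cc1` (not yet measured)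

Compound 3 holds the lowest of the three numbers (11%), its gap to compound 2 within the scatter and its gap to compound 1 beyond it. Compound 4 carries 4-chlorophenyl in place of 3-fluorophenyl on a saturated chain carbon bound to an aromatic carbon. Three measured steps change this same place: a number 6 percentage points lower from compound 1 to compound 2 (within the scatter) and a number 8 percentage points lower from compound 2 to compound 3 (within the scatter) and also a number 14 percentage points lower from compound 1 to compound 3 (beyond the scatter) as the only one beyond the scatter. None involves 4-chlorophenyl, so the data fix no direction, and only a slight drift upward from the low number of compound 3 (11%) is expected in this assay here. The expected change is small (a number 6 percentage points higher from compound 3 to compound 4 (within the scatter)), with no step beyond the scatter. For compound 4 the estimated value is 17% with 6% to 30% as the expected range.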

Compound 4, percent growth inhibition at one concentration: 15%
Compound 4: the middle estimate sits 2 percentage points above what was measured, and the stated range covers the measured number.
By their numbers in this assay, from the lowest: compounds 3, 4, 2 and 1 (each within the scatter of the next, the first and the last beyond it).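

In this assay the 4-chlorophenyl group gives steps that all stay within the scatter, with a number 4 percentage points higher from compound 3 to compound 4 (within the scatter) and a number 4 percentage points lower from compound 2 to compound 4 (within the scatter) and a number 10 percentage points lower from compound 1 to compound 4 (within the scatter) as the three readings. Compound 4 therefore cannot be ordered against any of the other three compounds, although it is the only one within the scatter of both compound 1 and compound 3. No supporting measurement bears on these small differences.

Still open, going by these compounds, is whether an amine or a carboxylic acid on the phenyl ring would shift growth inhibition. On these data alone, a longer chain in place of the benzyl carbon is equally open.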